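The source may hold more compounds than are shown below. What is called first, only, known or untested is meant among the compounds shown, and "the series" means these compounds.

Of the compounds shown here, two have so far been tested in a functional assay on SGC-7901 cells (Homo sapiens) for cytotoxicity, read by MTT assay, with a stated time of 48 h; on this read-out lower numbers stand for stronger inhibition and higher numbers for weaker inhibition. Compound 1 `Cc1ncc([N+](=O)[O-])n1CCSc1nnc(-c2ccc(N)cc2)o1` gives 31700 nM in this assay, and compound 2 `COc1ccc(-c2nnc(SCCn3c([N+](=O)[O-])cnc3C)o2)c(O)c1` gives 11700 nM. Of these two numbers, compound 1 stands highest, and compound 2 sits below it by a step beyond the usual scatter. Compound 3 `Cc1ncc([N+](=O)[O-])n1CCSc1nnc(-c2ccc(N)nc2)o1` has not yet been measured. It differs from compound 1 in one place: 6-aminopyridin-3-yl in place of 4-aminophenyl on an aromatic carbon. Among the compounds with values here, no measured pair shows such a change, so only a small step is expected, within the scatter and in no fixed direction. For compound 3 the value is estimated at 30000 nM, with a range from 10000 nM to 90000 nM. This estimate means an expected step of a 1.1-fold lower number from compound 1 to compound 3 (0.02 log units; within the scatter).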

Compound 3, half-maximal inhibitory concentration: 30900 nM
Estimate against measurement, compound 3: 1.0-fold (0.01 log units) below; low and high end bracket the measured number.
By their numbers in this assay, from the lowest: compound 2; then compounds 3 and 1 (each within the scatter of the next).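

In this assay, within the data shown here, the change from 4-aminophenyl to 6-aminopyridin-3-yl gives a 1.0-fold lower number from compound 1 to compound 3 (0.01 log units; within the scatter) and is the first comparison of compounds that differ in one place. At this position, then, a ring with 1 hetero atom and an added hydrogen-bond acceptor can stand in for the carbon-only ring with no difference beyond the scatter. The compounds shown leave open whether a different group on this ring, such as a carboxylic acid or a nitrile, would shift the number. No measurement at hand gives a reason for the match between these two rings.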